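The source may report more compounds than this note shows. Statements on the series, on what has been measured and on what is new or still open speak of the compounds shown alone.

Working notes on the series, the step from compound 2 to compound 4.

Of the compounds shown here, three have been measured in an assay on HEK293 cells for displacement of a labelled ligand from Neuronal acetylcholine receptor; alpha3/beta4 (Homo sapiens), read by radioligand binding, with a stated time of 5 min; a lower number here means a stronger inhibitor, a higher number a weaker inhibitor. Compound 1, `OCc1cc(F)cc(C2=NCCCC2)c1`, gives 80 nM. Compound 2, `Fc1cccc(C2=NCCCC2)c1`, gives 108 nM. Compound 3, `Brc1cc(Br)cc(C2=NCCCC2)c1`, gives 70.8 nM. The number for compound 2 stands alongside those of compound 1 and compound 3: the gaps to both are within the scatter, so no order among the three can be read from these figures. For the measured compounds named here, the one single-point step in the set, a 1.4-fold higher number from compound 1 to compound 2 (0.13 log units; within the scatter), is also within the scatter.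

Compound 4, `Ic1cccc(C2=NCCCC2)c1`, differs from compound 2 by iodo in place of fluoro on an aromatic carbon. Going by the values given here, no measured step exchanges one halogen for another; the nearest point of comparison is compound 3, whose value in this assay and that of compound 2 are within the scatter of each other. On that basis no step beyond the scatter is expected from compound 2 to compound 4, and the estimated step is a 1.2-fold lower number from compound 2 to compound 4 (0.08 log units; within the scatter). Compound 4 is expected to give about 90 nM in this assay, with a plausible range from 40 nM to 200 nM.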

Compound 4, inhibition constant: 4.7 nM
Beside the measured number, compound 4's estimate is 19-fold (1.28 log units) above it; measured number outside the range, below it.
By their numbers in this assay, from the lowest: compound 4; then compounds 3, 1 and 2 (each within the scatter of the next).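

In this assay, a 23-fold lower number from compound 2 to compound 4 (1.36 log units; beyond the scatter) shows that this aromatic carbon, meta to a group of 6 heavy atoms, is not indifferent to which halogen it carries: exchanging fluoro for iodo, one heavy atom for one heavy atom, is enough to move the number well beyond the scatter. For the compounds shown here, the only earlier single-place step, a 1.4-fold higher number from compound 1 to compound 2 (0.13 log units; within the scatter), lay within the scatter and concerned hydroxymethyl and hydrogen on another aromatic carbon, so it gave no sign that a change of this size was available. No measurement given here explains why iodo and fluoro differ so widely at this carbon.

Open, as far as these compounds go, is whether the step belongs to iodo alone or would also appear with a single chloro or bromo on the same carbon, which would show whether the number falls gradually along the halogens or only at iodo, and whether a group without halogen, such as methyl, methoxy or an amine, could match it there. Also open, from the compounds shown here alone, is whether the low number of compound 4 would hold with a hydroxymethyl on a further aromatic carbon, or with any change to the shared core.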